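Series notes: chain-end exchange on compound 1

The compounds below may be only part of what the source reports. "The series", "measured", "known", "first", "only" and "open" are said of these compounds alone.

Measured so far:
compound 1, `NS(=O)(=O)CC(=O)NCCSc1nonc1/C(=N/O)Nc1ccc(F)c(C(F)F)c1`, gives 13 nM in an assay for inhibition of Indoleamine 2,3-dioxygenase 1 (Homo sapiens), read by fluorescence, with a stated time of 24 h; on this read-out lower numbers stand for stronger inhibition and higher numbers for weaker inhibition
compound 2, `N#Cc1cccc(N/C(=N\O)c2nonc2SCCNC(=O)CS(N)(=O)=O)c1`, gives 44 nM in this assay
compound 3, `NS(=O)(=O)CC(=O)NCCSc1nonc1/C(=N/O)Nc1cccc(Br)c1`, gives 8.1 nM in this assay

Compound 1 stands second highest of the three numbers. Its step to compound 3 is a 1.6-fold lower number from compound 1 to compound 3 (0.21 log units; within the scatter); its step to compound 2 is a 3.4-fold higher number from compound 1 to compound 2 (0.53 log units; beyond the scatter). The remaining step is a 5.4-fold lower number from compound 2 to compound 3 (0.73 log units; beyond the scatter).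

Compound 4, `CC(C)(O)CC(=O)NCCSc1nonc1/C(=N/O)Nc1ccc(F)c(C(F)F)c1`, differs from compound 1 by 1-hydroxy-1-methylethyl in place of sulfamoyl on a saturated chain carbon bound to a carbonyl carbon. Within the data shown here, every measured step exchanges the aryl group on the amine nitrogen; none touches the chain end, so no measured step bears directly on this change. With no guiding data, the step is estimated as a 1.5-fold higher number from compound 1 to compound 4 (0.19 log units; within the scatter), none beyond the scatter. Compound 4 is therefore expected to give 20 nM, within a range of 6 nM to 65 nM.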

Compound 4, half-maximal inhibitory concentration: 8.4 nM
The estimate for compound 4 lay 2.4-fold (0.38 log units) above the measured number; the measured number falls inside the stated range.
By their numbers in this assay, from the lowest: compounds 3, 4 and 1 (each within the scatter of the next); then compound 2.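

At the chain end, 1-hydroxy-1-methylethyl in place of sulfamoyl gives a 1.5-fold lower number from compound 1 to compound 4 (0.19 log units; within the scatter), so on this core sulfamoyl is not needed for a number in this range. Compounds 1 to 3 vary only the aryl group on the amine nitrogen, while compound 4 shows that a group without sulfur or nitrogen can stand on this saturated chain carbon. No available measurement bears on why the two groups read alike.

Open, going by these compounds, is whether an amine, a carboxylic acid or a longer chain at this end would read alike. Also open, on these data alone, is whether 1-hydroxy-1-methylethyl holds with 3-bromophenyl or 3-cyanophenyl on the amine nitrogen.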